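Trading a Catechol Ester for a Short Branched Chain

The source may report more compounds than this note shows. Statements on the series, on what has been measured and on what is new or still open speak of the compounds shown alone.

Three glycosidic esters sharing one core have been measured in a functional assay on HeLa cells (Homo sapiens) for antiproliferative activity, read by MTT assay, with a stated time of 72 h; a higher number here means a weaker inhibitor, a lower number a stronger inhibitor. Compound 1, `C/C=C1/[C@H](O[C@@H]2O[C@H](COC(C)=O)[C@@H](OC(C)=O)[C@H](OC(C)=O)[C@H]2OC(C)=O)OC=C(C(=O)OC)[C@H]1CC(=O)OCCC`, with its fully acetylated sugar and a propyl ester, gives 17500 nM. Compound 2, `C/C=C1/[C@H](O[C@@H]2O[C@H](CO)[C@@H](O)[C@H](O)[C@H]2O)OC=C(C(=O)OC)[C@H]1CC(=O)OCCc1ccc(O)c(O)c1`, carries a free sugar and a 2-(3,4-dihydroxyphenyl)ethyl ester and gives 265000 nM, the highest number of the three and therefore the weakest inhibitor; its distance to compound 1 and to compound 3 is beyond the scatter in each case. Compound 3, `C/C=C1/[C@H](O[C@@H]2O[C@H](CO)[C@@H](O)[C@H](O)[C@H]2O)OC=C(C(=O)OC)[C@H]1CC(=O)OCCCCCCCCCCCCCCC`, with a pentadecyl ester, gives 2700 nM, the lowest number of the set.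

Compound 4, `C/C=C1/[C@H](O[C@@H]2O[C@H](CO)[C@@H](O)[C@H](O)[C@H]2O)OC=C(C(=O)OC)[C@H]1CC(=O)OCCC(C)C`, has not been measured. It differs from compound 2 in one place: isopropyl in place of 3,4-dihydroxyphenyl on a saturated chain carbon, two bonds along the chain from an oxygen next to a carbonyl group. Going by the values given here, no step between measured compounds matches this change, so only the spread of the three values guides the expectation. Because compound 2 gives 265000 nM while the plain-chain ester of compound 3 gives 2700 nM, a drop in the number is expected, with the estimated step being a 5.9-fold lower number from compound 2 to compound 4 (0.77 log units; beyond the scatter). Compound 4 is thus expected to give about 45000 nM in this assay, within a range from 12000 nM to 170000 nM.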

Compound 4, half-maximal inhibitory concentration: 19500 nM
For compound 4 the middle estimate is 2.3-fold (0.36 log units) above the measured one; the measured number falls inside the stated range.
By their numbers in this assay, from the lowest: compound 3; then compounds 1 and 4 (each within the scatter of the next); then compound 2.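

In this assay, going by these compounds alone, replacing the 2-(3,4-dihydroxyphenyl)ethyl ester with an isopentyl ester gives a 14-fold lower number from compound 2 to compound 4 (1.13 log units; beyond the scatter), a large step and the first single-place comparison at this position. It shows that, on the free sugar and shared core, the aromatic ring and its two hydroxyl groups are not required for activity in this assay, since a branched chain without a ring gives the lower number. Nothing available explains the size of this step.

The compounds shown do not separate the contribution of the ring from that of its hydroxyl groups, a question that a plain 2-phenylethyl ester would address. Going by these compounds, with compound 3, the pentadecyl ester, at 2700 nM and compound 4 at 19500 nM, it also remains open how intermediate chains such as octyl or dodecyl would behave.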